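The source may hold more compounds than are shown below. What is called first, only, known or untested is meant among the compounds shown, and "the series" means these compounds.

Compound 1 `O=C(/C=C/c1ccc(Br)cc1)c1ccc[nH]1`: in an assay for inhibition of cytochrome P450 1A1 (Homo sapiens), read by fluorescence, using microsomes, with a stated time of 10 min (on this read-out lower numbers stand for stronger inhibition and higher numbers for weaker inhibition), compound 1 gives > 20000 nM, a limit of the assay.
Compound 2 `O=C(/C=C/c1ccc(OC(F)(F)F)cc1)c1ccc[nH]1`: in this assay compound 2 gives > 20000 nM, likewise a limit.

Compound 2 therefore stands at the limit of the assay, where compound 1 also sits: the limit of > 20000 nM in this assay, at which 2 of the 2 values shown sit. Among the measured compounds shown here, the only measured step is a step that the two limits leave unreadable from compound 1 to compound 2, and with both ends at the limit its size cannot be read.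

Compound 3 `COc1ccc(/C=C/C(=O)c2ccc[nH]2)cc1` differs from compound 2 by methyl in place of trifluoromethyl on an oxygen on an aromatic ring. For the measured compounds named here, no measured step speaks to this change, so no movement beyond the scatter is expected in this assay in either direction. The step this estimate means is expected to be a step that the limit leaves unreadable from compound 2 to compound 3. Compound 3 is expected to give about 30000 nM, with a range from 8000 nM to 100000 nM.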

Compound 3, half-maximal inhibitory concentration: > 20000 nM
Compound 3: no number, only a limit; the forecaster's own chance of this, stated with the estimate: 75%; the middle value does not contradict the limit.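

In this assay, among the compounds shown here, compound 3 gives > 20000 nM, again a limit, so no step among compound 1, compound 2 and compound 3 can be read. The compounds shown leave open whether exchanging these groups changes inhibition at all.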